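A Halogen Swap on the Weakest of Three Compounds

The compounds below may be only part of what the source reports. "The series", "measured", "known", "first", "only" and "open" are said of these compounds alone.

In a functional assay on SK-OV-3 cells (Homo sapiens) (a lower number here means a stronger inhibitor of growth, a higher number a weaker inhibitor of growth), compound 1 (`O=S(=O)(/C=C/c1ccc(Cl)cc1Cl)Cc1ccc(Nc2ncnc3ccccc23)cc1`) gives 2000 nM. Compound 2 (`O=S(=O)(/C=C/c1ccc(Cl)cc1Cl)Cc1ccc(Nc2ncnc3ccc(Br)cc23)cc1`) gives 1000 nM, with a 2.0-fold lower number from compound 1 to compound 2 (0.30 log units; within the scatter). Compound 3 (`O=S(=O)(/C=C/c1ccc(Cl)cc1Cl)Cc1ccc(Nc2ncnc3cc(Cl)ccc23)cc1`) has the highest number of the three at 48000 nM, with a 24-fold higher number from compound 1 to compound 3 (1.38 log units; beyond the scatter).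

Compound 4 (`O=S(=O)(/C=C/c1ccc(F)cc1Cl)Cc1ccc(Nc2ncnc3cc(Cl)ccc23)cc1`) carries fluoro in place of chloro on an aromatic carbon, para to a large group: fluoro in place of chloro on an aromatic carbon. Both measured steps alter the shared core and leave the 2,4-dichlorophenyl group untouched, so neither bears directly on this change. Going by the values given here, with no measured step to suggest otherwise, the expectation stays anchored on compound 3 at 48000 nM, and no shift beyond the scatter is expected, the estimate being a 1.2-fold lower number from compound 3 to compound 4 (0.08 log units; within the scatter). Compound 4 is expected at 40000 nM, with an estimated range from 15000 nM to 100000 nM.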

Compound 4, concentration for 50% growth inhibition: > 100000 nM
Compound 4: only a limit was reported; the forecaster's own chance of this, stated with the estimate: 25%; at least 2.5-fold (0.39 log units) between middle value and limit.
By their numbers in this assay, from the lowest: compounds 2 and 1 (each within the scatter of the next); then compound 3. At a limit, above all of these: compound 4.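

Going by these compounds alone, changing the 2,4-dichlorophenyl group to 2-chloro-4-fluorophenyl gives an at least 2.0-fold higher number from compound 3 to compound 4 (0.31 log units; beyond the scatter), so this position, untouched by the earlier steps, is not silent in this assay. This is the first step shown outside the shared core that lies beyond the scatter, and even a single halogen swap here registers. The value of compound 4 is a limit and not a number: the limit of > 100000 nM in this assay, at which 1 of the 4 values shown sits.

From the compounds shown here alone, it remains open whether the same swap would also raise the number on the core of compound 1 or compound 2. Going by these compounds, how a methoxy group or an amine would read at this position also remains open.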